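The compounds below may be only part of what the source reports. "The series", "measured", "known", "first", "only" and "open" are said of these compounds alone.

Series notes. Compound 1 `O=C(CCc1ccccc1)Nc1nc2ccccc2c(=O)s1` and compound 2 `COc1cccc(/C=C/CC(=O)Nc2nc3ccccc3c(=O)s2)c1` share one core and differ in the chain on the amide. In an assay on CHO cells for displacement of a labelled ligand from adenosine receptor A1 (Homo sapiens), read by scintillation counting, with a stated time of 90 min (on this read-out lower numbers stand for stronger inhibition and higher numbers for weaker inhibition), compound 1 gives 1050 nM, and compound 2 gives 500 nM, the lower of the two numbers, its gap to compound 1 lying beyond the scatter. Compound 3 `O=C(C/C=C/c1cccc(Cl)c1)Nc1nc2ccccc2c(=O)s1` is not yet measured; it carries chloro in place of methoxy on an aromatic carbon. For the measured compounds named here, no step between measured compounds shows what this exchange does, so the expectation for compound 3 in this assay is a step no larger than the scatter in either direction, a 1.1-fold lower number from compound 2 to compound 3 (0.05 log units; within the scatter). Compound 3 is estimated at 450 nM, within 150 nM to 1500 nM.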

Compound 3, inhibition constant: 562 nM
Beside the measured number, compound 3's estimate is 1.2-fold (0.10 log units) below it, and the stated range covers the measured number.
By their numbers in this assay, from the lowest: compounds 2, 3 and 1 (each within the scatter of the next, the first and the last beyond it).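

In this assay, for the compounds shown here, 3-methoxyphenyl to 3-chlorophenyl gives a 1.1-fold higher number from compound 2 to compound 3 (0.05 log units; within the scatter), the first single-place step. At this position, meta to a large group, chloro can stand in place of methoxy without a change beyond the scatter, even though the hydrogen-bond acceptor counted for methoxy leaves. No measurement at hand offers an explanation for this result.

From the compounds shown here alone, whether an amine or a carboxylic acid at this position would fit equally well remains open. The compounds shown also leave open how a longer chain on the amide would read.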